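Para-Chloro Substitution on Two Thromboxane Antagonist Scaffolds

A few compounds are considered here, and "the series" means these few. Any claim that something is new, unique, unknown or untested is made for them only; others in the source may bear on it.

Measured compounds:
Compound 1, `CC(C)c1ccc2c(CCC/C=N/N=C(\S)Nc3ccccc3)cc(C(=O)O)c-2cc1`; in a functional assay on thoracic aorta for antagonist activity at thromboxane A2 receptor (Rattus norvegicus) (on this read-out higher numbers stand for weaker inhibition and lower numbers for stronger inhibition), compound 1 gives 590000 nM.
Compound 2, `CC(C)c1ccc2c(CCC/C=N/N=C(\S)Nc3ccc(Cl)cc3)cc(C(=O)O)c-2cc1`; compound 2 reaches only a limit of this assay, namely > 100000 nM.
Compound 3, `CC(C)c1ccc2c(CCCCS(=O)(=O)Nc3ccccc3)cc(S(=O)(=O)O)c-2cc1`; in this assay compound 3 gives 1500 nM.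

The change from compound 1 to compound 2 is chloro in place of hydrogen on an aromatic carbon. The step it made is a step that the limit leaves unreadable from compound 1 to compound 2; its size cannot be read because of the limit of > 100000 nM in this assay, at which 1 of the 3 values shown sits, at which the value of compound 2 sits.

Compound 3 rests on a different core; the difference between the core of compound 1 and the core of compound 3 is not broken down here. Of the two readable numbers in this assay, compound 3 holds the lower one, and compound 1 lies well beyond the scatter above it.

Compound 4, `CC(C)c1ccc2c(CCCCS(=O)(=O)Nc3ccc(Cl)cc3)cc(S(=O)(=O)O)c-2cc1`, has not yet been measured. It differs from compound 3 by chloro in place of hydrogen on an aromatic carbon, the same change as from compound 1 to compound 2, at the same kind of place on the aromatic ring. The earlier step gives no readable size, so the expectation for compound 4 rests only on compound 3, whose value in this assay is 1500 nM, and on the small size of the change. The step from compound 3 to compound 4 in this assay is estimated at a 1.3-fold lower number from compound 3 to compound 4 (0.10 log units; within the scatter). Compound 4 is expected to give about 1200 nM in this assay, with the estimate ranging from 300 nM to 5000 nM.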

Compound 4, half-maximal inhibitory concentration: 220 nM
The estimate for compound 4 lay 5.5-fold (0.74 log units) above the measured number, outside the stated range (below it).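

In this assay, chloro in place of hydrogen, which turns phenyl into 4-chlorophenyl on the core of compound 3, gives a real gain, with a 6.8-fold lower number from compound 3 to compound 4 (0.83 log units; beyond the scatter). This is the only readable size for the change in the compounds shown, since compound 2 gives only a limit of the assay, > 100000 nM, and that limit is not a number, so the step on the core of compound 1 cannot be read and no comparison of the two steps can be made: the limit of > 100000 nM in this assay, at which 1 of the 4 values shown sits. The result therefore shows that the change can matter on one core, in one pair of compounds, but it does not show that the change carries from one core to the other, nor does it explain why the number falls.

What the compounds shown leave open is whether another group at the same place on the aromatic ring, such as fluoro, bromo or methoxy, would give a step like that of chloro on the core of compound 3. As far as these compounds go, it also remains open whether the step would survive a change elsewhere in the molecule, such as a longer chain or a tetrazole in place of the sulfonic acid.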